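The source may hold more compounds than are shown below. What is called first, only, known or untested is meant among the compounds shown, and "the series" means these compounds.

Measured in a functional assay on SF-268 cells (Homo sapiens) for inhibition (on this read-out higher numbers stand for weaker inhibition and lower numbers for stronger inhibition), are these compounds:
Compound 1 `N#Cc1c(/N=C/c2ccccc2)sc2c1CCCC2` gives 20 nM
Compound 2 `N#Cc1c(/N=C/n2nc(N)cc2O)sc2c1CCCC2` gives 60 nM

Of these two, compound 2 has the higher number: compound 2 gives 60 nM and compound 1 gives 20 nM. The gap between the two lies beyond the usual scatter. Compound 3 `CCOC(=O)c1c(/N=C/n2nc(N)cc2O)sc2c1CCCC2` carries ethoxycarbonyl in place of cyano on an aromatic carbon. Within the data shown here, no measured pair shows this change, so the expectation is tentative: a moderate rise in the number in this assay and thus weaker inhibition. The expected move is a 2.0-fold higher number from compound 2 to compound 3 (0.30 log units; within the scatter) on this estimate. Compound 3 is expected to read 120 nM (estimated range 30 nM to 500 nM).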

Compound 3, half-maximal inhibitory concentration: 50 nM
Estimate against measurement, compound 3: 2.4-fold (0.38 log units) above; measured number inside the range.
By their numbers in this assay, from the lowest: compound 1; then compounds 3 and 2 (each within the scatter of the next).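

In this assay, ethoxycarbonyl in place of cyano on this aromatic carbon gives a 1.2-fold lower number from compound 2 to compound 3 (0.08 log units; within the scatter). With the amino-hydroxy-bearing side group held fixed, this position therefore takes either group without a change that this read-out can separate from scatter. Nothing available accounts for the two groups reading alike. As far as these compounds go, whether a carboxylic acid or a primary amide on this carbon would also read alike remains open. So does whether the same exchange would behave this way in compound 1, which carries a different side group.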